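A few compounds are considered here, and "the series" means these few. Any claim that something is new, unique, unknown or untested is made for them only; others in the source may bear on it.

In a functional assay on Jurkat cells (Homo sapiens) for antiproliferative activity, read by MTT assay, with a stated time of 48 h (on this read-out higher numbers stand for weaker inhibition and lower numbers for stronger inhibition), compound 1 (`COC(=O)/C=C/c1ccc2c(c1)C(=O)C(=O)N2Cc1ccccc1`) gives 70 nM, while compound 2 (`COC(=O)/C=C/c1ccc2c(c1)C(=O)C(=O)N2Cc1ccc(OC)cc1`) gives 30 nM, the lower of the two numbers. Compound 3 (`COC(=O)/C=C/c1ccc2c(c1)C(=O)C(=O)N2Cc1cc(C)cc(C)c1`) has 3,5-dimethylphenyl in place of 4-methoxyphenyl on a saturated chain carbon bound to an amide-type nitrogen in a ring. Within the data shown here, only one measured step bears on this change: a 2.3-fold lower number from compound 1 to compound 2 (0.37 log units; beyond the scatter), a modest step that came with methoxy in place of hydrogen on an aromatic carbon. Among the measured compounds shown here, compound 3 lacks that methoxy, and no measured compound carries 3,5-dimethylphenyl, so a modest rise is expected in this assay. The estimated step is a 2.0-fold higher number from compound 2 to compound 3 (0.30 log units; within the scatter). For compound 3 the expected value is 60 nM, within an estimated range of 22 nM to 160 nM.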

Compound 3, half-maximal inhibitory concentration: 620 nM
The estimate for compound 3 lay 10-fold (1.01 log units) below the measured number; measured number outside the range, above it.
By their numbers in this assay, from the lowest: compound 2; then compound 1; then compound 3.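

In this assay, among these compounds, this place on the saturated chain carbon proves far more sensitive than the earlier compounds suggested: 3,5-dimethylphenyl in place of 4-methoxyphenyl gives a 21-fold higher number from compound 2 to compound 3 (1.32 log units; beyond the scatter) and the loss of inhibition is large. Measured against plain phenyl, the same group gives an 8.9-fold higher number from compound 1 to compound 3 (0.95 log units; beyond the scatter) and so falls behind the unsubstituted ring as well. Adding groups to this phenyl ring therefore does not by itself strengthen inhibition: the methoxy of compound 2 lowers the number, while the two methyl groups of compound 3 raise it. How 4-ethoxyphenyl or 4-chlorophenyl would behave at this place stays open, and nothing measured here gives a reason for the rise.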